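A few compounds are considered here, and "the series" means these few. Any claim that something is new, unique, unknown or untested is made for them only; others in the source may bear on it.

Measured so far in a functional assay on the whole organism for inhibition, with Rattus norvegicus as the target, read by paw edema, with stated times of 1 h and 4 h, at a dose of 0.03 mg/kg by the oral route; a lower number here means less inhibition, a higher number more inhibition at the dose given (going by the name of the read-out):
- compound 1 `CC1=NN(C(=O)c2cc3ccccc3oc2=O)C(=O)C1CNc1ccccn1` gives 31.1%
- compound 2 `CC1=NN(C(=O)c2cc3ccccc3oc2=O)C(=O)C1CNc1cccc(S(N)(=O)=O)c1` gives 67.8%
- compound 3 `COc1ccc(NCC2C(=O)N(C(=O)c3cc4ccccc4oc3=O)N=C2C)cc1` gives 36.1%

Compound 3 stands second highest of the three numbers. Its nearest neighbour is compound 1, the step being a number 5 percentage points higher from compound 1 to compound 3 (within the scatter); its furthest is compound 2, the step being a number 31.7 percentage points lower from compound 2 to compound 3 (beyond the scatter). The one large effect in the set is a number 36.7 percentage points higher from compound 1 to compound 2 (beyond the scatter), which, like the other two steps, changes the whole aryl group on the amine nitrogen.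

Compound 4 `CC1=NN(C(=O)c2cc3ccccc3oc2=O)C(=O)C1CNc1ccc([N+](=O)[O-])cc1` differs from compound 3 in one place: nitro in place of methoxy on an aromatic carbon. Among the compounds with values here, no measured step exchanges one substituent on that phenyl ring for another, so the three steps bear on it only indirectly: they show that the aryl group on the amine nitrogen can move this assay by a large amount, or leave it within the scatter. A step in this assay of undetermined direction, and not clearly beyond the scatter, is therefore expected, a number 5.9 percentage points higher from compound 3 to compound 4 (within the scatter). Compound 4 is estimated at 42%, in the range 25% to 62%.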

Compound 4, a percentage reported as inhibition, in the whole organism at one dose (the size of the read-out at that dose, not a potency): 61.9%
Compound 4: the middle estimate sits 19.9 percentage points below what was measured, within the range that was stated.
By their numbers in this assay, from the lowest: compounds 1 and 3 (each within the scatter of the next); then compounds 4 and 2 (each within the scatter of the next).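

In this assay, within the data shown here, the first exchange of one substituent for another on the phenyl ring, para to a large group, moves the number clearly (a number 25.8 percentage points higher from compound 3 to compound 4 (beyond the scatter)), so this place is not silent. The high end of the set also no longer rests on the 3-sulfamoylphenyl group alone (a number 5.9 percentage points lower from compound 2 to compound 4 (within the scatter)), and the 4-nitrophenyl group separates from the pyridin-2-yl group as well (a number 30.8 percentage points higher from compound 1 to compound 4 (beyond the scatter)). No data on the origin of these steps are at hand.

Open, on these data alone, is whether the step is specific to nitro or would recur with an amine, a carboxylic acid or a nitrile at the same place. A 3-nitrophenyl or 4-sulfamoylphenyl group would separate the identity of the substituent from its place on the ring.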